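Mouse microsomal clearance: replacing trifluoromethyl in compound 1

The source may hold more compounds than are shown below. What is called first, only, known or untested is meant among the compounds shown, and "the series" means these compounds.

In an ADME assay on microsomes (Mus musculus) for metabolic stability (on this read-out higher numbers stand for fast clearance and lower numbers for slow clearance), compound 1 `CNC(=O)[C@@H]1CCCN1S(=O)(=O)c1ccc(Cl)c(COc2cccc3c(C(F)(F)F)cc(C)nc23)c1Cl` gives 1380 mL/min/kg, within the scatter of compound 3 `COC[C@@H]1CCCN1S(=O)(=O)c1ccc(Cl)c(COc2cccc3c(C(F)(F)F)cc(C)nc23)c1Cl` at 1620 mL/min/kg. Compound 2 `Cc1cc(C(F)(F)F)c2cccc(OCc3c(Cl)ccc(S(=O)(=O)N4CCC[C@H]4C(=O)O)c3Cl)c2n1` stands far lower at 13.3 mL/min/kg. Compound 4 `CNC(=O)[C@@H]1CCCN1S(=O)(=O)c1ccc(Cl)c(COc2cccc3c(-c4nccn4C)cc(C)nc23)c1Cl` is the next case, with 1-methyl-1H-imidazol-2-yl in place of trifluoromethyl on an aromatic carbon. For the measured compounds named here, no measured step touches that carbon. The nearest guides lie elsewhere in the molecule: a 1.2-fold higher number from compound 1 to compound 3 (0.07 log units; within the scatter) is small, while a 100-fold lower number from compound 1 to compound 2 (2.02 log units; beyond the scatter) is large and brings in the carboxy group. Compound 4 carries no such group, so no step beyond the scatter is expected in this assay. The expected step is a 1.4-fold lower number from compound 1 to compound 4 (0.14 log units; within the scatter). For compound 4 the estimated clearance is 1000 mL/min/kg, with an expected range of 350 mL/min/kg to 2200 mL/min/kg.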

Compound 4, clearance: 917 mL/min/kg
For compound 4 the middle estimate is 1.1-fold (0.04 log units) above the measured one, within the range that was stated.
By their numbers in this assay, from the lowest: compound 2; then compounds 4, 1 and 3 (each within the scatter of the next).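

On the aromatic carbon opposite the ring nitrogen, 1-methyl-1H-imidazol-2-yl in place of trifluoromethyl gives a 1.5-fold lower number from compound 1 to compound 4 (0.18 log units; within the scatter) in this assay. This carbon therefore accepts a five-membered aromatic ring with 2 hetero atoms without a step beyond the scatter in this read-out, although clearance stays high. Nothing available explains this outcome. From the compounds shown here alone, an amine or a nitrile on this carbon remains open, as does whether the carboxy step, a 100-fold lower number from compound 1 to compound 2 (2.02 log units; beyond the scatter), carries over when 1-methyl-1H-imidazol-2-yl is present.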